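The source may report more compounds than this note shows. Statements on the series, on what has been measured and on what is new or still open speak of the compounds shown alone.

Compound 1 `COC(=O)NC1=NC(c2cccc(C)c2)CN1` and compound 2 `COC(=O)NC1=NC(c2cc(C)ccc2C)CN1` share one core; compound 3 `COC(=O)NC1=NC(c2ccccc2)CN1C` and compound 4 `COC(=O)NC1=NC(c2ccccc2C)CN1C` share another, and the difference between the two cores is not broken down here. In a functional assay on the whole organism for antagonist activity, with Mus musculus as the target, in the maximal electroshock model (on this read-out lower numbers stand for an effect already at smaller amounts and higher numbers for an effect only at larger amounts of compound), compound 1 gives 100 mg/kg, compound 2 gives about 100 mg/kg and compound 3 gives 107 mg/kg. The change from compound 1 to compound 2, (methyl in place of hydrogen on an aromatic carbon), gave no change at the digits printed from compound 1 to compound 2 (within the scatter). The change from compound 3 to compound 4 is methyl in place of hydrogen on an aromatic carbon; it is the same kind of change, not the same, since in compound 2 the entering methyl is also para to a methyl group and in compound 4 it is not. Because no change at the digits printed from compound 1 to compound 2 (within the scatter), the same kind of step in this assay is expected to be a 1.0-fold lower number from compound 3 to compound 4 (0.01 log units; within the scatter). Compound 4 is therefore estimated at 105 mg/kg in this assay.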

Compound 4, dose for half-maximal effect: 68 mg/kg
Compound 4: middle estimate off by 1.5-fold (0.19 log units), on the high side, and the stated range covers the measured number.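

In this assay, methyl in place of hydrogen on an aromatic carbon gives a 1.6-fold lower number from compound 3 to compound 4 (0.20 log units; within the scatter). Set beside the earlier step, the two steps do not separate: the same change on two cores in this assay, no change at the digits printed (within the scatter) from compound 1 to compound 2 and a 1.6-fold lower number (0.20 log units; within the scatter) from compound 3 to compound 4, 1.6-fold (0.20 log units) apart, within the scatter of two such steps. Carrying this change between the two cores therefore fits the data within the scatter, but this rests on only two steps and does not show that the change would behave alike on any further core or at another ring position.

Still open, as far as these compounds go, is how a larger or different group, such as ethyl, a longer chain, an amine or a carboxylic acid, would behave in place of that hydrogen. From the compounds shown here alone, whether any such group would give a step beyond the scatter on either core also remains open.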